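Replacing 1-acetylpiperidin-4-yl in compound 2

The compounds below may be only part of what the source reports. "The series", "measured", "known", "first", "only" and "open" are said of these compounds alone.

Of the compounds shown here, two have numbers so far in an ADME assay (liver, Mus musculus) for metabolic stability, using microsomes; a lower number here means that the compound disappears faster, a higher number that the compound lasts longer. Compound 1 `C=CC(=O)Nc1cccc(CNc2nc(Nc3cn(C)nc3C)ncc2Cl)c1` gives 0.138 h, and compound 2 `C=CC(=O)Nc1cccc(CNc2nc(Nc3cnn(C4CCN(C(C)=O)CC4)c3)ncc2Cl)c1` gives 0.05 h, the lower of the two numbers and a gap beyond the usual scatter. Compound 3 `C=CC(=O)Nc1cccc(CNc2nc(Nc3cnn(CCN(C)C)c3)ncc2Cl)c1` keeps the shared core and the rest of compound 2, but carries 2-(dimethylamino)ethyl in place of 1-acetylpiperidin-4-yl on an aromatic nitrogen. Going by the values given here, no measured pair differs in this one place, so the data give no direct guide to the size of this step. Among the compounds with values here, the only guide is the gap between the two measured compounds, and compound 3 is expected to fall within it. A small rise is therefore expected, an estimated 1.6-fold higher number from compound 2 to compound 3 (0.20 log units; within the scatter), and it may not clear the scatter. Compound 3 is estimated at 0.08 h, with an expected range of 0.04 h to 0.18 h.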

Compound 3, half-life: 0.03 h
Compound 3: the middle estimate sits 2.7-fold (0.43 log units) above what was measured; the measured number lies below the stated range.
By their numbers in this assay, from the lowest: compounds 3 and 2 (each within the scatter of the next); then compound 1.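

In this assay, 2-(dimethylamino)ethyl in place of 1-acetylpiperidin-4-yl on the aromatic nitrogen gives a 1.7-fold lower number from compound 2 to compound 3 (0.22 log units; within the scatter), so these two groups cannot be told apart at this position, even though one carries a six-membered non-aromatic ring and the other has no ring. Exchanging the whole 1,3-dimethyl-1H-pyrazol-4-yl for 1-(2-(dimethylamino)ethyl)-1H-pyrazol-4-yl gives a 4.6-fold lower number from compound 1 to compound 3 (0.66 log units; beyond the scatter), a step that does clear the scatter and leaves compound 2 and compound 3 together at the low end of the three numbers. Nothing available bears on the cause of either step.

Going by these compounds, whether a carboxylic acid, a morpholine ring or a longer chain on that aromatic nitrogen would move the half-life beyond the scatter of compound 3 remains open. The step from compound 1 alters the ring's two methyl groups together, leaving their separate shares unresolved.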